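The source may hold more compounds than are shown below. What is called first, only, known or untested is meant among the compounds shown, and "the series" means these compounds.

Measured compounds:
compound 1, `CCCc1nc(-c2ccccc2)c(CNCCN2CCN(c3ccc(Cl)cc3)CC2)o1`, 2820 nM
compound 2, `CCCc1nc(-c2ccccc2)c(CNCCCN2CCN(c3ccc(F)cc3)CC2)o1`, 3210 nM

Of the compounds shown here, two have been tested in an assay on HEK293 cells for inhibition of Voltage-dependent T-type calcium channel subunit alpha-1G (Homo sapiens), read by patch clamp; a lower number here means a stronger inhibitor, a higher number a weaker inhibitor. Compound 1 gives 2820 nM, and compound 2 gives 3210 nM in this assay. The two values lie within the usual scatter of each other, so compound 1 stands level with compound 2 on these numbers, and no ranking between them can be read from the data.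

Compound 3, `CCCc1nc(-c2ccccc2)c(CNCCN2CCN(c3cccc(C)c3C)CC2)o1`, has not yet been measured. It differs from compound 1 in one place: 2,3-dimethylphenyl in place of 4-chlorophenyl on an amine nitrogen in a ring. Within the data shown here, no measured pair shows what this kind of change does here, so the data give no support for a step beyond the scatter in either direction. Compound 3 is expected to move little, if at all: a 1.1-fold higher number from compound 1 to compound 3 (0.03 log units; within the scatter). Compound 3 is therefore estimated at 3000 nM in this assay, with a range from 1200 nM to 8000 nM.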

Compound 3, half-maximal inhibitory concentration: 1710 nM
For compound 3 the middle estimate is 1.8-fold (0.24 log units) above the measured one; measured number inside the range.
By their numbers in this assay, from the lowest: compounds 3, 1 and 2 (each within the scatter of the next).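

In this assay the change from 4-chlorophenyl to 2,3-dimethylphenyl on an amine nitrogen in a ring gives a 1.6-fold lower number from compound 1 to compound 3 (0.22 log units; within the scatter) and this step lies within the scatter. Among these compounds, this is the first pair that differs in one place, and it shows that these two groups can be exchanged here without a change that can be told from the scatter. Nothing available explains why the two groups read alike. Going by these compounds, whether a pyridine ring or a benzyl group on the same nitrogen would give a step beyond the scatter remains open. The effect of a longer chain between the two amine nitrogens, taken on its own, also remains open, as no pair shown isolates that change.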